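A Nitro Group on the Benzylamine Side Chain

The compounds below may be only part of what the source reports. "The series", "measured", "known", "first", "only" and "open" are said of these compounds alone.

Compound 1 `C=C1CC[C@@H]2[C@](C)(CNCc3ccccc3)[C@H](O)CC[C@@]2(C)[C@@H]1/C=C/C1=CCOC1=O`: 960 nM
Compound 2 `C=C1CC[C@@H]2[C@](C)(CNCc3ccc(C#N)cc3)[C@H](O)CC[C@@]2(C)[C@@H]1/C=C/C1=CCOC1=O`: 1130 nM

In a functional assay on BMMC cells (Mus musculus, strain C57BL/6) for inhibition, with stated times of 5 days and 48 h (on this read-out higher numbers stand for weaker inhibition and lower numbers for stronger inhibition), compound 1 gives 960 nM, the lower of the two numbers shown, while compound 2 gives 1130 nM; the step of a 1.2-fold higher number from compound 1 to compound 2 (0.07 log units; within the scatter) stays within the scatter. Compound 3 `C=C1CC[C@@H]2[C@](C)(CNCc3ccc([N+](=O)[O-])cc3)[C@H](O)CC[C@@]2(C)[C@@H]1/C=C/C1=CCOC1=O` differs from compound 1 by nitro in place of hydrogen on an aromatic carbon. Among the measured compounds shown here, the one measured step that bears on this change is the cyano step, a 1.2-fold higher number from compound 1 to compound 2 (0.07 log units; within the scatter), which did not move the read-out beyond the scatter. Compound 3 is therefore expected to show no shift beyond the scatter, with a 1.1-fold higher number from compound 1 to compound 3 (0.06 log units; within the scatter) as the estimated step. The estimate for compound 3 is 1100 nM, expected to lie between 500 nM and 2400 nM.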

Compound 3, half-maximal inhibitory concentration: 1340 nM
Beside the measured number, compound 3's estimate is 1.2-fold (0.09 log units) below it, and the stated range covers the measured number.
By their numbers in this assay, from the lowest: compounds 1, 2 and 3 (each within the scatter of the next).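

In this assay, nitro in place of hydrogen gives a 1.4-fold higher number from compound 1 to compound 3 (0.14 log units; within the scatter) and nitro in place of cyano gives a 1.2-fold higher number from compound 2 to compound 3 (0.07 log units; within the scatter) on the same aromatic carbon, para to a large group. Cyano is thus no longer the only group at this place whose step stays within the scatter, and the two groups cannot be told apart here. No evidence is available to explain this result.

From the compounds shown here alone, whether an amine or a carboxylic acid at this place would stay within the scatter remains open, as does the effect of nitro elsewhere on the ring.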